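A few compounds are considered here, and "the series" means these few. Any claim that something is new, unique, unknown or untested is made for them only; others in the source may bear on it.

In an ADME assay on Caco-2 cells (Homo sapiens) for permeability, read by LC-MS, in the apical to basolateral direction, with a stated time of 2 h (a higher number here means that the compound crosses the layer faster, a lower number that the compound crosses the layer more slowly), compound 1 `COc1cc(C(=O)N2CCC(O)CC2)cc2nc(NCc3cccc(Cl)c3)oc12` gives 71 nm/s and compound 2 `COc1cc(C(=O)N2CC[C@@H](O)[C@H](C)C2)cc2nc(NCc3cccc(Cl)c3)oc12` gives 126 nm/s, so these two cannot be told apart. Compound 3 `COc1cc(C(=O)N2CC(C)C(O)CC2C2CC2)cc2nc(NCc3cccc(Cl)c3)oc12` differs from compound 2 as follows: 2-cyclopropyl-4-hydroxy-5-methylpiperidin-1-yl in place of 4-hydroxy-3-methylpiperidin-1-yl on a carbonyl carbon. Among the compounds with values here, the one measured step that bears on this is a methyl in place of hydrogen on a saturated ring carbon, a 1.8-fold higher number from compound 1 to compound 2 (0.25 log units; within the scatter). Within the data shown here, no measured compound carries a cyclopropyl group, so the data give no firm direction, and no change beyond the scatter is expected. The expected result is a 1.1-fold lower number from compound 2 to compound 3 (0.02 log units; within the scatter). For compound 3, the estimated value is 120 nm/s, within a range of 50 nm/s to 280 nm/s.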

Compound 3, apparent permeability: 138 nm/s
Compound 3: middle estimate off by 1.2-fold (0.06 log units), on the low side, within the range that was stated.
By their numbers in this assay, from the lowest: compounds 1, 2 and 3 (each within the scatter of the next).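

In this assay, putting 2-cyclopropyl-4-hydroxy-5-methylpiperidin-1-yl in place of 4-hydroxy-3-methylpiperidin-1-yl on the carbonyl carbon gives a 1.1-fold higher number from compound 2 to compound 3 (0.04 log units; within the scatter). Set against 4-hydroxypiperidin-1-yl, the same group gives a 1.9-fold higher number from compound 1 to compound 3 (0.29 log units; within the scatter). This place on the carbonyl carbon therefore takes a larger group carrying a cyclopropyl ring without a reading that can be told apart from the earlier two. Nothing available explains this result. Going by these compounds, it remains open whether an amine or a carboxylic acid on this piperidine ring would shift the number beyond the scatter.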